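Pyrrolidinyl Replacement at the Oxadiazole-Linked Amine

The source may hold more compounds than are shown below. What is called first, only, known or untested is meant among the compounds shown, and "the series" means these compounds.

Measured: compound 1 `CCCCCCCCCCc1ccc(-c2noc(CCCCN)n2)cc1`, 55%; compound 2 `CCCCCCCCCCc1ccc(-c2noc(CCCN(C)C)n2)cc1`, 8%.

In an assay on HeLa cells for inhibition of sphingosine-1-phosphate transporter SPNS2 (Mus musculus), read by LC-MS, tested at 2 uM (a lower number here means less inhibition, a higher number more inhibition at the concentration tested (going by the name of the read-out)), compound 2 stands lowest of the two numbers, with compound 1 higher. The unmeasured compound 3 `CCCCCCCCCCc1ccc(-c2noc(C3CCNC3)n2)cc1` differs from compound 2 by pyrrolidin-3-yl in place of 3-(dimethylamino)propyl on an aromatic carbon. Going by the values given here, only one measured step bears on this region: a number 47 percentage points lower from compound 1 to compound 2 (beyond the scatter), a large fall when the amine end was altered, so the amine end matters here. The new group brings 1 hydrogen-bond donor, as compound 1's chain did. Compound 3 is therefore expected to rise, by a number 27 percentage points higher from compound 2 to compound 3 (beyond the scatter), to an estimated 35%, between 10% and 65%.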

Compound 3, a percentage reported as inhibition, at one concentration (the size of the read-out at that concentration, not a potency): 26%
Compound 3: middle estimate off by 9 percentage points, on the high side, within the range that was stated.
By their numbers in this assay, from the lowest: compound 2; then compound 3; then compound 1.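

In this assay, pyrrolidin-3-yl on the aromatic carbon gives a rise of a number 18 percentage points higher from compound 2 to compound 3 (beyond the scatter), but against 4-aminobutyl it shows a fall of a number 29 percentage points lower from compound 1 to compound 3 (beyond the scatter). Compound 3 thus ranks above compound 2 and below compound 1, so carrying 1 hydrogen-bond donor, as compound 1 does, does not by itself match compound 1. No available evidence explains either step. The compounds shown do not separate the effect of the ring from that of the chain length. As far as these compounds go, a piperidine ring, or a longer chain ending in a methylamino group, remains open.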